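Nitrile to trifluoromethyl on a shared core

A few compounds are considered here, and "the series" means these few. Any claim that something is new, unique, unknown or untested is made for them only; others in the source may bear on it.

Of the compounds shown here, two built on one shared core have so far been measured in an ADME assay on Huh-7 cells (Homo sapiens) for cytotoxicity, read by MTT assay, with a stated time of 48 h; on this read-out higher numbers stand for lower toxicity in this test and lower numbers for higher toxicity in this test. Compound 1 `COc1ccc(-c2nn(Cc3ccc(NC(=O)OCCCCN(C)C)cc3)c(=O)c3ccccc23)cc1` gives 20300 nM. Compound 2 `CN(C)CCCCOC(=O)Nc1ccc(Cn2nc(-c3ccc(C#N)cc3)c3ccccc3c2=O)cc1` gives 37000 nM. Going by the values given here, the one measured step, a 1.8-fold higher number from compound 1 to compound 2 (0.26 log units; within the scatter), lies within the scatter, so compound 2 stands at one end of the two numbers without a separation that counts.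

Compound 3 `CN(C)CCCCOC(=O)Nc1ccc(Cn2nc(-c3ccc(C(F)(F)F)cc3)c3ccccc3c2=O)cc1` has not been measured. It differs from compound 2 in one place: trifluoromethyl in place of cyano on an aromatic carbon. Among the compounds with values here, the only measured step that bears on this change is the exchange of a methoxy for a cyano on the same aromatic carbon, and that step stayed within the scatter; no measured step involves a trifluoromethyl. On this basis, no step beyond the scatter is expected in this assay. Compound 3 is therefore estimated at 35000 nM, within a range from 15000 nM to 85000 nM. The expected step is a 1.1-fold lower number from compound 2 to compound 3 (0.02 log units; within the scatter).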

Compound 3, half-maximal cytotoxic concentration: 3360 nM
Estimate against measurement, compound 3: 10-fold (1.02 log units) above; the whole stated range lies above it.
By their numbers in this assay, from the lowest: compound 3; then compounds 1 and 2 (each within the scatter of the next).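

In this assay, the group on this aromatic carbon, para to a large group, now proves able to shift the read-out: trifluoromethyl in place of cyano gives an 11-fold lower number from compound 2 to compound 3 (1.04 log units; beyond the scatter) and trifluoromethyl in place of methoxy gives a 6.0-fold lower number from compound 1 to compound 3 (0.78 log units; beyond the scatter), whereas methoxy and cyano themselves stay within the scatter of each other. Compound 3 therefore stands apart from both other compounds, on the side of higher toxicity in this test. No measurement shown here accounts for this separation.

The compounds shown leave open whether the lower number belongs to trifluoromethyl alone or would also appear with a chlorine atom, an amine or a carboxylic acid at this place. They also leave open whether this exchange would give a step of similar size on a compound with a shorter or longer chain in place of the one shared here.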